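The source may hold more compounds than are shown below. What is called first, only, known or untested is meant among the compounds shown, and "the series" means these compounds.

Measured so far:
compound 1, `Nc1ncnc2c1ncn2/C=C1\C[C@@H]1[C@H](O)CO` — in an ADME assay on HFF cells (Homo sapiens) for cytotoxicity, read by neutral red uptake (on this read-out lower numbers stand for higher toxicity in this test and higher numbers for lower toxicity in this test), compound 1 gives > 300000 nM, which is a limit of the assay and not a number.
compound 2, `Nc1nc2c(ncn2/C=C2\C[C@@H]2[C@@H](O)CO)c(=O)[nH]1` — in this assay compound 2 gives > 300000 nM, again a limit of the assay rather than a number.

Compound 1 therefore stands at the edge of what this test can report, and the same holds for the other value shown: the limit of > 300000 nM in this assay, at which 2 of the 2 values shown sit. For the measured compounds named here, no step between two measured compounds is given, so nothing here shows how a change in configuration moves the read-out.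

Compound 3, `Nc1ncnc2c1ncn2/C=C1/C[C@@H]1[C@@H](O)CO`, has not yet been measured. The difference from compound 1 is the two compounds have the same atoms and bonds and differ only in configuration as drawn: 2 of 3 stereo elements differ; a stereocentre at a saturated chain carbon is drawn S in compound 1 and R in compound 3; a double bond is drawn E in compound 1 and Z in compound 3. With both measured compounds sitting at the limit, the step from compound 1 to compound 3 is expected to be none beyond the scatter, as a step that the limit leaves unreadable from compound 1 to compound 3. Compound 3 is expected to give about 400000 nM, within roughly 150000 nM to 1000000 nM, and most probably to come back as a limit again.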

Compound 3, half-maximal cytotoxic concentration: > 300000 nM
Compound 3 was reported as a limit; the forecaster's own chance of this, stated with the estimate: 80%; the middle value does not contradict the limit.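

In this assay compound 3 gives > 300000 nM, a limit and not a number. No step can therefore be read between compound 1 and compound 3: the limit of > 300000 nM in this assay, at which 3 of the 3 values shown sit.

The compounds shown leave open whether the stereocentre or the double bond configuration, taken alone, affects the read-out in this assay.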